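Phenyl for methyl in a weak growth inhibitor

This account rests on a few compounds, and the source may have more. Where it says the series, first, only, none or still open, it means among the compounds named here.

Of the compounds shown here, three have been measured in a functional assay (Homo sapiens) for inhibition; a lower number here means a stronger inhibitor of growth, a higher number a weaker inhibitor of growth. Compound 1 `COc1ccc(/C=C2\CN(C)Cc3c2nc(O)c(C#N)c3-c2ccc(OC)cc2)cc1` gives > 100000 nM, which is a limit of the assay and not a number. Compound 2 `CN1C/C(=C\c2cccs2)C2=NN(C)C(c3cccs3)C2C1` gives > 100000 nM, which is likewise a limit and not a number. Compound 3 `CN1CC2=C(OC(N)=C(C#N)C2c2cccs2)/C(=C/c2cccs2)C1` is the only one of the three with a number, at 87300 nM.

Compound 4 `CN1C/C(=C\c2cccs2)C2=NN(c3ccccc3)C(c3cccs3)C2C1`, not yet measured, differs from compound 2 by phenyl in place of methyl on an amine nitrogen in a ring, next to the ring atom that bears a thiophen-2-yl group: phenyl in place of methyl on an amine nitrogen in a ring. Within the data shown here, no step between measured compounds shows what such a change does, so the expectation is a loose one. Among the measured compounds shown here, compound 3, at 87300 nM, gives the only measured number to lean on, and compound 4 is expected to stay in that region of this assay. The expected at least 1.2-fold lower number from compound 2 to compound 4 (0.09 log units; that floor lies within the scatter) is small and, if it can be seen at all, runs towards stronger inhibition of growth. For compound 4 the estimated value is 80000 nM, with an expected range from 30000 nM to 100000 nM.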

Compound 4, concentration for total growth inhibition: 87100 nM
Beside the measured number, compound 4's estimate is 1.1-fold (0.04 log units) below it; the range from low to high includes it.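

In this assay, among these compounds, the change from methyl to phenyl on this amine nitrogen in a ring gives the first readable step at this position: an at least 1.1-fold lower number from compound 2 to compound 4 (0.05 log units; that floor lies within the scatter). Compound 2 gives > 100000 nM, which is a limit and not a number. From the compounds shown here alone, with phenyl on this nitrogen, compound 4 has a measured number where the methyl compound has only a limit, but the true size of the change stays unknown because compound 2 sits at that limit: the limit of > 100000 nM in this assay, at which 2 of the 4 values shown sit.

The compounds shown leave open whether an ethyl chain, a benzyl group or a pyridyl ring on this nitrogen would give a different number. They also leave open what a methoxy group or a carboxylic acid on the phenyl ring would do in this assay.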